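Replacing Methylsulfonylphenyl with Nitrophenyl on the Shared Core

This account rests on a few compounds, and the source may have more. Where it says the series, first, only, none or still open, it means among the compounds named here.

Compound 1 `Cc1cccc(/C=N/Nc2ncc3c(n2)n(C2CCCC2)c(=O)c(=O)n3C)c1` gives 53600 nM in a functional assay on PC-3 cells (Homo sapiens) for antiproliferative activity, read by MTT assay; on this read-out higher numbers stand for weaker inhibition and lower numbers for stronger inhibition.
Compound 2 `Cn1c(=O)c(=O)n(C2CCCC2)c2nc(N/N=C/c3ccc(Cl)cc3)ncc21` gives 8420 nM in this assay.
Compound 3 `Cn1c(=O)c(=O)n(C2CCCC2)c2nc(N/N=C/c3ccc(S(C)(=O)=O)cc3)ncc21` gives 26600 nM in this assay.

Among these three numbers compound 3 stands second highest. Its nearest neighbour is compound 1, reached by a 2.0-fold lower number from compound 1 to compound 3 (0.30 log units; within the scatter), a difference within the scatter; its furthest is compound 2, reached by a 3.2-fold higher number from compound 2 to compound 3 (0.50 log units; beyond the scatter), a modest step beyond the scatter.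

Compound 4 `Cn1c(=O)c(=O)n(C2CCCC2)c2nc(N/N=C/c3cccc([N+](=O)[O-])c3)ncc21` differs from compound 3 in one place: 3-nitrophenyl in place of 4-(methylsulfonyl)phenyl on a carbon with a double bond to nitrogen. The three measured steps all change this same group on the carbon with a double bond to nitrogen, so they bear on the change. They were a 6.4-fold lower number from compound 1 to compound 2 (0.80 log units; beyond the scatter), a 2.0-fold lower number from compound 1 to compound 3 (0.30 log units; within the scatter) and a 3.2-fold higher number from compound 2 to compound 3 (0.50 log units; beyond the scatter). None of them involves 3-nitrophenyl, and the three values cover only a modest span, so no direction can be read off with confidence.

Compound 4 is therefore estimated at about 20000 nM, with a range from 7000 nM to 60000 nM. The step this estimate means, a 1.3-fold lower number from compound 3 to compound 4 (0.12 log units; within the scatter), is expected to stay within or near the scatter in this assay.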

Compound 4, half-maximal inhibitory concentration: 20300 nM
Compound 4: middle estimate off by 1.0-fold (0.01 log units), on the low side; measured number inside the range.
By their numbers in this assay, from the lowest: compound 2; then compounds 4, 3 and 1 (each within the scatter of the next, the first and the last beyond it).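

In this assay, 3-nitrophenyl and 4-(methylsulfonyl)phenyl on the carbon with a double bond to nitrogen cannot be told apart, with a 1.3-fold lower number from compound 3 to compound 4 (0.12 log units; within the scatter) as the step, so two different groups on the phenyl ring can give nearly the same reading. The new compound also shows that the ring's substituent matters in a pair that keeps the 3-substituted pattern: a 2.6-fold lower number from compound 1 to compound 4 (0.42 log units; beyond the scatter) is a modest step beyond the scatter for nitro in place of methyl, yet 4-chlorophenyl still keeps the lowest number of the four, with a 2.4-fold higher number from compound 2 to compound 4 (0.38 log units; beyond the scatter) as its step to the new compound. Nothing shown here explains why these groups fall in this order.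

Going by these compounds, it remains open whether compound 2 stands apart through the chloro group itself or through where that group sits on the ring, and a 3-chlorophenyl or a 4-nitrophenyl group at this place would separate those two readings. Also open, on these data alone, is how a phenyl ring carrying an amine or a carboxylic acid would read in this assay, and whether any such group could bring the number below that of compound 2.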